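The compounds below may be only part of what the source reports. "The series", "measured", "known", "first", "only" and "open" are said of these compounds alone.

In a functional assay on CHO cells with adenosine receptor A1 (Homo sapiens) as the target, read by cAMP accumulation and immunoassay, with a stated time of 6 min, tested at 0.1 uM (on this read-out lower numbers stand for a stronger effect and higher numbers for a weaker effect at the one concentration tested), two compounds built on a shared core have been measured. Compound 1 `Nc1scc(CN2CCN(c3ccc(Cl)cc3F)CC2)c1C(=O)c1ccc(Cl)cc1` gives -9.4%, and compound 2 `Nc1scc(CN2CCN(c3ccc(F)c(Cl)c3)CC2)c1C(=O)c1ccc(Cl)cc1` gives -21%. The two differ only in the aryl group on the ring amine nitrogen, and the step of a number 11.6 percentage points lower from compound 1 to compound 2 (beyond the scatter) shows that such a swap can move the read-out beyond the usual scatter. Compound 2 thus stands as the lower of the two numbers, with compound 1 above it by a gap beyond the scatter.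

Compound 3 `Nc1scc(CN2CCN(c3ccccc3Cl)CC2)c1C(=O)c1ccc(Cl)cc1` has not yet been measured. Its change from compound 2 is 2-chlorophenyl in place of 3-chloro-4-fluorophenyl on an amine nitrogen in a ring. For the measured compounds named here, the only measured step that bears on this change is a number 11.6 percentage points lower from compound 1 to compound 2 (beyond the scatter), which also swapped the aryl group at the same place and was modest. A step of similar size is therefore expected, though one example cannot fix its direction; because compound 2 holds the lowest value -21% a drift back toward the level of compound 1 is taken as somewhat more likely. The expected step is a number 8 percentage points higher from compound 2 to compound 3 (within the scatter). For compound 3 the estimate is -13%, within a range from -30% to 4%.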

Compound 3, a percentage reported as activity, at one concentration (the size of the read-out at that concentration, not a potency): 2%
Compound 3: middle estimate off by 15 percentage points, on the low side; measured number inside the range.
By their numbers in this assay, from the lowest: compound 2; then compound 1; then compound 3.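

In this assay, the aryl group on the ring amine nitrogen can also push the read-out toward a weaker effect: there is a number 23 percentage points higher from compound 2 to compound 3 (beyond the scatter), and there is a number 11.4 percentage points higher from compound 1 to compound 3 (beyond the scatter). Both steps are of modest size, yet together they place compound 3 as the weakest of the three at the one concentration tested, so this position responds in both directions to changes among halogen-bearing phenyl groups. The 2-chlorophenyl group carries no fluorine and differs from both earlier groups in where its chlorine sits, so these compounds cannot separate the loss of fluorine from the change in chlorine position, and nothing available here explains the shift.

The compounds shown leave open how a plain unsubstituted phenyl, or a phenyl bearing a methoxy group instead of a halogen, would read at this position. They also leave open whether this order would hold across a range of concentrations, as each number here describes the size of the effect at one concentration and is not a potency.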